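The source may hold more compounds than are shown below. What is called first, only, known or untested is meant among the compounds shown, and "the series" means these compounds.

- Compound 1 `C=C/C=C\[C@H](C)[C@H](OC(N)=O)[C@@H](C)[C@H](O)[C@@H](C)C[C@@](C)(O)[C@H]1[C@H](C)[C@@H](O)[C@@H](C)[C@@H]1/C=C/C[C@@H]1OC(=O)[C@H](C)[C@@H](O)[C@H]1C`: 2360 nM
- Compound 2 `C=C/C=C\[C@H](C)[C@H](OC(N)=O)[C@@H](C)[C@H](O)[C@@H](C)C[C@](C)(O)[C@H]1[C@H](C)[C@@H](O)[C@@H](C)[C@@H]1/C=C/C[C@@H]1OC(=O)[C@H](C)[C@@H](O)[C@H]1C`: 1730 nM

Both values come from a functional assay on MCF7 cells (Homo sapiens) for cytotoxicity; on this read-out lower numbers stand for stronger inhibition and higher numbers for weaker inhibition. For the measured compounds named here, compound 2 stands level with compound 1, its only neighbour. Compound 3 `C=C/C=C\[C@H](C)[C@H](OC(N)=O)[C@@H](C)[C@H](O)[C@H](C)C[C@](C)(O)[C@H]1[C@H](C)[C@@H](O)[C@@H](C)[C@@H]1/C=C/C[C@@H]1OC(=O)[C@H](C)[C@@H](O)[C@H]1C` differs from compound 2 as follows: the two compounds have the same atoms and bonds and differ only in configuration as drawn: 1 of 17 stereo elements differ; a stereocentre at a saturated chain carbon is drawn S in compound 2 and R in compound 3. Going by the values given here, only one measured step bears on this, a change at another stereocentre: a 1.4-fold lower number from compound 1 to compound 2 (0.13 log units; within the scatter). One small step is thin evidence, so the range stays wide, and no change beyond the scatter is expected in this assay. The expected step is a 1.2-fold higher number from compound 2 to compound 3 (0.06 log units; within the scatter). For compound 3 the estimated value is 2000 nM, with an expected range of 700 nM to 6000 nM.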

Compound 3, half-maximal inhibitory concentration: 7350 nM
Compound 3: middle estimate off by 3.7-fold (0.57 log units), on the low side; measured number above the stated range.
By their numbers in this assay, from the lowest: compounds 2 and 1 (each within the scatter of the next); then compound 3.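

Changing the configuration at this one saturated chain carbon gives a 4.2-fold higher number from compound 2 to compound 3 (0.63 log units; beyond the scatter), whereas the change at the other stereocentre gave only a 1.4-fold lower number from compound 1 to compound 2 (0.13 log units; within the scatter), so these two stereocentres do not count alike. With both changed at once, the gap is a 3.1-fold higher number from compound 1 to compound 3 (0.49 log units; beyond the scatter). The larger step can be traced to the arrangement at this carbon alone because no atom or bond changes: the fact that compounds 2 and 3 differ only in the configuration as drawn

Still open, on these data alone, is how the number would respond to an ethyl group or a fluorine atom at this carbon. The compounds shown also leave open whether either drawn configuration would then keep its place.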